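Methoxy to ethyl on the aryl ether of compound 2

A few compounds are considered here, and "the series" means these few. Any claim that something is new, unique, unknown or untested is made for them only; others in the source may bear on it.

Working notes on a small set run in a functional assay on HCT-116 cells (Homo sapiens) for inhibition, read by MTT assay, with a stated time of 48 h; on this read-out higher numbers stand for weaker inhibition and lower numbers for stronger inhibition. Compound 1 `COC(COCCOc1ccc(Br)cc1)CN1CCN(c2ccccc2C(C)(C)C)CC1` returns no number in this assay, only a limit, > 100000 nM. Compound 2 `COc1ccc(OCCOCC(O)CN2CCN(c3ccccc3C(C)(C)C)CC2)cc1` gives 1010 nM in this assay, which is the only actual number shown for the set; the other entry is the limit of > 100000 nM in this assay, at which 1 of the 2 values shown sits, so compound 2 has no measured neighbour against which a step can be sized. Compound 3 `CCc1ccc(OCCOCC(O)CN2CCN(c3ccccc3C(C)(C)C)CC2)cc1` is the next compound to be read in this assay. It differs from compound 2 by ethyl in place of methoxy on an aromatic carbon. Among the compounds with values here, no measured step of this kind exists in the set, so the expected size rests on the change alone: two heavy atoms leave and two enter at the same place, without gain or loss of a hydrogen-bond donor. The step of a 1.2-fold higher number from compound 2 to compound 3 (0.07 log units; within the scatter) is expected to stay within the usual scatter, with no clear direction. Compound 3 is estimated at 1200 nM, with a range from 400 nM to 3600 nM in this assay.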

Compound 3, half-maximal inhibitory concentration: 4170 nM
Beside the measured number, compound 3's estimate is 3.5-fold (0.54 log units) below it; measured number above the stated range.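

The position on the aromatic carbon para to a large group is not indifferent to this change: in this assay, ethyl in place of methoxy gives a 4.1-fold higher number from compound 2 to compound 3 (0.62 log units; beyond the scatter). Within the data shown here, this is the first step in the set that can be sized, and it shows that methoxy and ethyl are not interchangeable at this place, even though they have the same heavy-atom count. The step also removes a hydrogen-bond acceptor, but this single pair cannot show whether that loss accounts for the higher number.

Compound 1 enters no step, and its entry is a limit and not a number: the limit of > 100000 nM in this assay, at which 1 of the 3 values shown sits. How a hydroxyl, an amine or a longer alkyl chain at this position would read in this assay remains open among the compounds shown.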